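The source may hold more compounds than are shown below. What is called first, only, known or untested is meant among the compounds shown, and "the series" means these compounds.

Measured compounds in a functional assay on SW480 cells (Homo sapiens) for antiproliferative activity, read by sulforhodamine B assay, with a stated time of 48 h; on this read-out higher numbers stand for weaker inhibition and lower numbers for stronger inhibition:

compound 1, `COc1ccc(C(=O)/C=C/c2ccccc2-c2ccc(F)nc2)cc1`: 10000 nM
compound 2, `COc1ccc(C(=O)/C=C/c2ccccc2-c2ccc(F)nc2)cc1OC`: 15000 nM
compound 3, `O=C(/C=C/c1ccccc1-c1ccc(F)cc1)c1cccc(O)c1`: 8700 nM

All three numbers lie within the usual scatter of one another, so no order among compound 1, compound 2 and compound 3 can be read from them. Compound 2 differs from compound 1 by methoxy in place of hydrogen on an aromatic carbon, and that change gave a 1.5-fold higher number from compound 1 to compound 2 (0.18 log units; within the scatter). The cores of compound 1 and compound 3 also differ; that difference between the two cores is not broken down here.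

Compound 4, `COc1ccc(C(=O)/C=C/c2ccccc2-c2ccc(F)cc2)cc1O`, has not yet been measured in this assay. It differs from compound 3 by methoxy in place of hydrogen on an aromatic carbon. Within the data shown here, this is the same kind of change as the one from compound 1 to compound 2, but not the same: in compound 4 the entering methoxy sits ortho to a hydroxy group and para to a large group, whereas in compound 2 it sits ortho to a methoxy group and meta to a large group.

Among the measured compounds shown here, with only one earlier example of this kind of change, and that one within the scatter, the expectation for compound 4 rests on the single step of a 1.5-fold higher number from compound 1 to compound 2 (0.18 log units; within the scatter) and on the value of compound 3, 8700 nM. The step from compound 3 to compound 4 is expected to be about a 1.3-fold higher number from compound 3 to compound 4 (0.10 log units; within the scatter), a small one, like the earlier step. Compound 4 is therefore estimated to give about 11000 nM in this assay, with a range from 5000 nM to 25000 nM.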

Compound 4, half-maximal inhibitory concentration: 340 nM
Compound 4: middle estimate off by 32-fold (1.51 log units), on the high side; the whole stated range lies above it.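

In this assay, methoxy in place of hydrogen on an aromatic carbon gave a 26-fold lower number from compound 3 to compound 4 (1.41 log units; beyond the scatter), so the size of this change did not carry from one core to the other: the same change on two cores in this assay, a 1.5-fold higher number (0.18 log units; within the scatter) from compound 1 to compound 2 and a 26-fold lower number (1.41 log units; beyond the scatter) from compound 3 to compound 4, 38-fold (1.58 log units) apart, beyond the scatter of two such steps

The two steps differ in more than the core, since the entering methoxy in compound 4 sits ortho to a hydroxy group and para to a large group, whereas its surroundings in compound 2 are not the same; these data do not separate the contribution of the core from that of the local surroundings. Among these compounds, with only two examples, the result shows that the step cannot be assumed to transfer between these two cores, but it gives no general rule for the series and no explanation for the gap, and the large step has been seen once, on the core of compound 3.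

Still open, on these data alone, is whether the core of compound 1 would show a similar step if it carried the hydroxy and methoxy arrangement of compound 4. Also open, as far as these compounds go, is whether the low number of compound 4 depends on the hydroxy group itself, and whether an ethoxy group or an amine in place of the entering methoxy would give a step of similar size.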